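Swapping a Butyl for a Butynyl Chain on a Ketone Core

This account rests on a few compounds, and the source may have more. Where it says the series, first, only, none or still open, it means among the compounds named here.

Measured in an assay on isolated protein for inhibition of Aromatase (Homo sapiens), read by fluorescence, with stated times of 10 min and 60 min (on this read-out lower numbers stand for stronger inhibition and higher numbers for weaker inhibition), three compounds are known:
compound 1, `CCCCCOc1ccc(C(=O)c2cccc(Cn3ccnc3)c2)cc1`, gives 42 nM;
compound 2, `CCCCCOc1ccc(C(=O)c2ccc(Cn3ccnc3)cc2)cc1`, gives 1300 nM;
compound 3, `CCC#CCOc1ccc(C(=O)c2ccc(Cn3ccnc3)cc2)cc1`, gives 1430 nM.

Compound 1 gives the lowest number of the three; both compound 2 and compound 3 give clearly higher numbers in this assay, so compound 1 is the strongest inhibitor among them.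

The next compound, compound 4, `CCC#CCOc1ccc(C(=O)c2cccc(Cn3ccnc3)c2)cc1`, is compound 1 with one change: but-1-yn-1-yl in place of butyl on a saturated chain carbon bound to an oxygen on an aromatic ring. The same exchange has already been made once, between compound 2 and compound 3, which share a core that differs from compound 1 only in where the imidazole-bearing arm sits. That step gave a 1.1-fold higher number from compound 2 to compound 3 (0.04 log units; within the scatter), meaning the chain exchange left the number essentially where it was.

Among the measured compounds shown here, only this one precedent bears on the question, and it comes from a different core, so some caution is due. Still, on that evidence no shift beyond the scatter is expected in this assay for compound 4; the estimated step is a 1.1-fold higher number from compound 1 to compound 4 (0.04 log units; within the scatter). Compound 4 is therefore expected to give about 46 nM, with a likely range from 20 nM to 110 nM.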

Compound 4, half-maximal inhibitory concentration: 9 nM
Estimate against measurement, compound 4: 5.1-fold (0.71 log units) above; measured number below the stated range.
By their numbers in this assay, from the lowest: compound 4; then compound 1; then compounds 2 and 3 (each within the scatter of the next).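

In this assay, the exchange of butyl for but-1-yn-1-yl on a saturated chain carbon bound to an oxygen on an aromatic ring does not always leave the number in place, as it gives a 4.7-fold lower number from compound 1 to compound 4 (0.67 log units; beyond the scatter). Butyl and but-1-yn-1-yl have the same count of heavy atoms and neither carries a hydrogen-bond donor or acceptor, so the listed difference between them is the triple bond, and this small exchange is enough to shift the number on the core of compound 1. The outcome of the exchange therefore depends on the core that carries it, and a result on one core does not transfer to the other: the same change on two cores in this assay, a 1.1-fold higher number (0.04 log units; within the scatter) from compound 2 to compound 3 and a 4.7-fold lower number (0.67 log units; beyond the scatter) from compound 1 to compound 4, 5.1-fold (0.71 log units) apart, beyond the scatter of two such steps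

The compounds shown leave open how a longer chain holding a triple bond, or a chain ending in a nitrile, would behave on the core of compound 1. Among the compounds shown here, with only one pair on each core, they also cannot tell whether this dependence on the core extends to any chain other than butyl and but-1-yn-1-yl.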